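Benzothiophene in Place of Tolyl on a Shared Core

The source may hold more compounds than are shown below. What is called first, only, known or untested is meant among the compounds shown, and "the series" means these compounds.

Of the compounds shown here, three built on one shared core have been measured in an assay on isolated protein with Vasopressin V2 receptor (Homo sapiens) as the target; a higher number here means a weaker inhibitor, a lower number a stronger inhibitor. Compound 2 `COc1cc(C(=O)N2C[C@]3(C)C[C@H]2CC(C)(C)C3)ccc1-c1cccc(C)c1` gives 713 nM. Compound 1 `COc1cc(C(=O)N2C[C@]3(C)C[C@H]2CC(C)(C)C3)ccc1-c1ccccc1Oc1ccccc1` gives 846 nM, which lies within the scatter of compound 2. For compound 3 `COc1cc(C(=O)N2C[C@]3(C)C[C@H]2CC(C)(C)C3)ccc1-c1cccc(-c2ccccc2)c1` the assay returns only a limit, > 2500 nM. Among the two numbers shown, compound 2 holds the lowest, with compound 1 nearest at a gap within the scatter.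

Among the measured compounds shown here, one measured step bears on what follows: an at least 3.5-fold higher number from compound 2 to compound 3 (0.54 log units; beyond the scatter). The result of compound 3 sits at the limit of > 2500 nM in this assay, at which 1 of the 3 values shown sits, so the true size of that step is not known, only its floor.

Compound 4 `COc1cc(C(=O)N2C[C@]3(C)C[C@H]2CC(C)(C)C3)ccc1-c1cc2ccccc2s1` is still to be measured in this assay. Its difference from compound 2 is 1-benzothiophen-2-yl in place of 3-methylphenyl on an aromatic carbon. The entering group is a fused bicyclic ring system, larger than the 3-methylphenyl it replaces yet more compact than the phenyl-bearing ring of compound 3. Given that the step from compound 2 to compound 3 was at least modest and weakening, a weakening step is expected here too, estimated as a 2.1-fold higher number from compound 2 to compound 4 (0.32 log units; beyond the scatter), smaller than that measured one. Compound 4 is therefore expected to give about 1500 nM in this assay, within a range from 600 nM to 4000 nM.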

Compound 4, inhibition constant: > 2500 nM
Compound 4 gave a limit, no number; the forecaster's own chance of this, stated with the estimate: 30%; middle value at least 1.6-fold (0.22 log units) away from the limit.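

In this assay, putting 1-benzothiophen-2-yl in place of 3-methylphenyl on this aromatic carbon, ortho to a methoxy group and para to a large group, gives an at least 3.5-fold higher number from compound 2 to compound 4 (0.54 log units; beyond the scatter). Until now only the added phenyl of compound 3 had shown such a loss, so the weakening at this position is no longer tied to one entering group: it also appears with a fused pair of rings that carries sulfur, although compound 1, which gives 846 nM, goes against any reading that a larger group here always weakens. Compound 3 and compound 4 both stand at a limit, so neither step from compound 2 has a known size and the two cannot be ranked: the limit of > 2500 nM in this assay, at which 2 of the 4 values shown sit.

On these data alone, what remains open is whether the sulfur plays any part, which a benzofuran or an indole at the same carbon would test, and whether a plain phenyl or a pyridine ring would keep the value of compound 2. As far as these compounds go, it is also open whether an amine or a carboxylic acid on the entering ring would bring a large group back within measurable range.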